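The compounds below may be only part of what the source reports. "The series", "measured", "known", "first", "only" and "open" are said of these compounds alone.

Measured compounds:
compound 1 `COc1cc(NC2=CC(=O)c3ncncc3C2=O)cc(OC)c1` — 16300 nM
compound 2 `O=C1C(Nc2ccc(-c3ccccc3)cc2)=CC(=O)c2ncncc21` — 500 nM
compound 3 `O=C1C(Nc2cccc(B(O)O)c2)=CC(=O)c2ncncc21` — > 10000 nM

Three compounds built on a shared core were tested in a functional assay on BXPC-3 cells (Homo sapiens) for cytotoxicity, read by MTT assay, with a stated time of 72 h; a higher number here means a weaker inhibitor, a lower number a stronger inhibitor. Compound 1 gives 16300 nM, and compound 2 gives 500 nM, the lowest of the two numbers obtained, with compound 1 standing a long way higher, well beyond the usual scatter. Compound 3 yielded no number in this assay; its result is a limit, > 10000 nM, as described by the limit of > 10000 nM in this assay, at which 1 of the 3 values shown sits.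

The next compound follows from compound 2. Compound 4 `CCc1ccc(-c2ccc(NC3=CC(=O)c4ncncc4C3=O)cc2)cc1` is compound 2 with one change: ethyl in place of hydrogen on an aromatic carbon. Among the compounds with values here, no measured pair in this set carries the same change, so the size of the step can only be expected, not read off. An ethyl group at this place on the outer ring is a small addition to a compound that already gives the best number seen, and the expectation is that the step from compound 2 to compound 4 in this assay stays within the usual scatter, leaning, if anywhere, toward a slightly lower number; the expected step is a 1.3-fold lower number from compound 2 to compound 4 (0.10 log units; within the scatter). On that basis compound 4 is estimated at 400 nM in this assay, within a range from 150 nM to 1200 nM.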

Compound 4, half-maximal inhibitory concentration: 3100 nM
For compound 4 the middle estimate is 7.8-fold (0.89 log units) below the measured one; the measured number lies above the stated range.
By their numbers in this assay, from the lowest: compound 2; then compound 4; then compound 1.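

In this assay, ethyl in place of hydrogen on an aromatic carbon of a six-membered aromatic ring of carbon only, para to a large group, gives a 6.2-fold higher number from compound 2 to compound 4 (0.79 log units; beyond the scatter), so this position does not tolerate even this small addition without a clear change in the read-out. Within the data shown here, the earlier compounds offered no pair differing in one place, which makes this the first direct reading of any single change on the shared core, and it shows that the phenyl to 4-ethylphenyl change moves the number upward, beyond the scatter. Nothing given here bears on what lies behind this step, which therefore stands as an observation without an explanation.

From the compounds shown here alone, it remains open whether the rise belongs to ethyl alone or would also appear with a methyl, a longer chain such as propyl, an amine or a carboxylic acid at the same place. Going by these compounds, it is also open whether ethyl would produce a step of similar size at another carbon of that ring, or on a compound other than compound 2.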